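From Lactone to Free Acid in a Thromboxane Synthase Series

A few compounds are considered here, and "the series" means these few. Any claim that something is new, unique, unknown or untested is made for them only; others in the source may bear on it.

Of the compounds shown here, three have been measured in a functional assay for inhibition of Thromboxane-A synthase (Homo sapiens); on this read-out lower numbers stand for stronger inhibition and higher numbers for weaker inhibition. Compound 1 `COC(=O)c1ccc(COC(COCc2ccc(OC)cc2)Cn2ccnc2)cc1` gives 1260 nM, compound 2 `COc1ccc(COCC(Cn2ccnc2)OCc2ccc(C(=O)OCc3ccccc3)cc2)cc1` gives 1490 nM, and compound 3 `COc1ccc(COCC(Cn2ccnc2)OCc2ccc3c(c2)COC3=O)cc1` gives 6200 nM, the highest of the three numbers, so compound 3 is the weakest inhibitor here. Compound 4 `COc1ccc(COCC(Cn2ccnc2)OCc2ccc(C(=O)O)cc2)cc1` differs from compound 3 by a group of 9 heavy atoms (7 carbon, 2 oxygen; one six-membered aromatic ring of carbon only) in place of a group of 10 heavy atoms (8 carbon, 2 oxygen; one five-membered non-aromatic ring with 1 hetero atom, one six-membered aromatic ring of carbon only), on a saturated chain carbon bound to an oxygen on a saturated carbon. Among the measured compounds shown here, two measured steps bear on this. The step of a 1.2-fold higher number from compound 1 to compound 2 (0.07 log units; within the scatter) shows that altering the group on the carbonyl oxygen barely moved the read-out. The step of a 4.9-fold higher number from compound 1 to compound 3 (0.69 log units; beyond the scatter) went with the arrival of the five-membered non-aromatic ring. Compound 4 removes that ring again and carries an open carboxyl group like compound 1, so a step back in the direction of compound 1 is expected: a 6.9-fold lower number from compound 3 to compound 4 (0.84 log units; beyond the scatter). Compound 4 is therefore estimated at 900 nM, with a range from 250 nM to 3500 nM.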

Compound 4, half-maximal inhibitory concentration: 6700 nM
Compound 4: the middle estimate sits 7.4-fold (0.87 log units) below what was measured; measured number outside the range, above it.
By their numbers in this assay, from the lowest: compounds 1 and 2 (each within the scatter of the next); then compounds 3 and 4 (each within the scatter of the next).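

Swapping the five-membered non-aromatic ring for 4-carboxyphenyl changes nothing measurable (a 1.1-fold higher number from compound 3 to compound 4 (0.03 log units; within the scatter)), so opening that ring does not bring back the lower numbers of the open esters. Removing the ester group has a real cost: hydrogen in place of methyl gives (a 5.3-fold higher number from compound 1 to compound 4 (0.73 log units; beyond the scatter)), and hydrogen in place of benzyl gives (a 4.5-fold higher number from compound 2 to compound 4 (0.65 log units; beyond the scatter)). At this position, an open ester is therefore linked to lower numbers than either the carboxylic acid or the closed ring.

As far as these compounds go, how a primary amide or a tetrazole would compare at this position remains open. Nothing available explains why the acid and the closed ring read alike.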